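Working notes: trifluoromethyl for tert-butyl, compound 3 to compound 4

The source may report more compounds than this note shows. Statements on the series, on what has been measured and on what is new or still open speak of the compounds shown alone.

Measured so far in a functional assay on cells (Lung cancer cell line, Homo sapiens) for antiproliferative activity; a higher number here means a weaker inhibitor of growth, a lower number a stronger inhibitor of growth:
Compound 1 `CCc1ccc2c(c1)C(c1ccccc1)(c1ccccc1)C(=O)N2`: > 20000 nM, a limit of the assay.
Compound 2 `O=C1Nc2ccc(S(=O)(=O)O)cc2C1(c1ccccc1)c1ccccc1`: 9000 nM.
Compound 3 `CC(C)(C)c1cccc(C2(c3ccc(O)cc3)C(=O)Nc3ccccc32)c1`: 4000 nM.

Compound 3 holds the lowest of the two numbers in this assay; compound 2 sits higher, beyond the scatter. Compound 1 stands only at a limit. Among the measured compounds shown here, the single measured step, an at least 2.2-fold lower number from compound 1 to compound 2 (0.34 log units; beyond the scatter), swaps different groups at a different place and so does not bear on the present change. Compound 4 `O=C1Nc2ccccc2C1(c1ccc(O)cc1)c1cccc(C(F)(F)F)c1` differs from compound 3 by trifluoromethyl in place of tert-butyl on an aromatic carbon. For the measured compounds named here, no measured step involves this exchange, so no shift beyond the scatter is expected in this assay. The expected step is no change at the digits printed from compound 3 to compound 4 (within the scatter). Compound 4 is estimated at 4000 nM, with a range from 1500 nM to 12000 nM.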

Compound 4, concentration for 50% growth inhibition: > 20000 nM
Compound 4: only a limit was reported; the forecaster's own chance of this, stated with the estimate: 5%; middle value at least 5.0-fold (0.69 log units) from the limit.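

In this assay, the group on this aromatic carbon, meta to a large group, matters: trifluoromethyl in place of tert-butyl gives an at least 5.0-fold higher number from compound 3 to compound 4 (0.69 log units; beyond the scatter). Compound 4 stands at a limit, > 20000 nM, so the step gives only a bound and not a full size. The same limit recurs in this short series: the limit of > 20000 nM in this assay, at which 2 of the 4 values shown sit.

From the compounds shown here alone, whether an amine, a carboxylic acid or a longer alkyl chain at this place would keep the number of compound 3 remains open. Two groups at this place support no trend.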